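The source may report more compounds than this note shows. Statements on the series, on what has been measured and on what is new or still open speak of the compounds shown alone.

The shared core carries a branched alkyl chain on one side and a phenethyl arm on the other, and the two measured compounds differ only in the aromatic group attached to the far end of that arm. Compound 1 `CCC(C)(C)Cc1c[nH]c(CCc2ccc(-n3ncnn3)cc2)n1` gives 89 nM in a functional assay on HEK293 cells for agonist activity at Bombesin receptor subtype-3 (Homo sapiens), read by luminescence and calcium flux, with a stated time of 10 min; on this read-out lower numbers stand for an effect already at smaller amounts and higher numbers for an effect only at larger amounts of compound. Compound 2 `CCC(C)(C)Cc1c[nH]c(CCc2ccc(-c3cccc(N)n3)cc2)n1` gives 97 nM in this assay . The only step measured so far, a 1.1-fold higher number from compound 1 to compound 2 (0.04 log units; within the scatter), shows that exchanging one small aromatic group for another at this position left the read-out essentially unchanged; on the two numbers shown, compound 2 therefore sits within the scatter of compound 1, with no ordering between them.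

Compound 3 `CCC(C)(C)Cc1c[nH]c(CCc2ccc(-c3cnsc3)cc2)n1` is formed from compound 2 by the change (1,2-thiazol-4-yl in place of 6-aminopyridin-2-yl on an aromatic carbon). For the measured compounds named here, the one step that bears on this is the exchange at the same position from compound 1 to compound 2, which stayed within the scatter. For compound 3 the expected step is therefore a 1.0-fold higher number from compound 2 to compound 3 (0.01 log units; within the scatter), with no change beyond the scatter. Compound 3 is estimated at 100 nM, in the range 40 nM to 250 nM.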

Compound 3, half-maximal effective concentration: 100 nM
The estimate for compound 3 equals the measured number at the digits printed; the measured number falls inside the stated range.
By their numbers in this assay, from the lowest: compounds 1, 2 and 3 (each within the scatter of the next).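

In this assay, replacing the six-membered 6-aminopyridin-2-yl with the five-membered 1,2-thiazol-4-yl gives a 1.0-fold higher number from compound 2 to compound 3 (0.01 log units; within the scatter), and replacing 2H-tetrazol-2-yl with the same group gives a 1.1-fold higher number from compound 1 to compound 3 (0.05 log units; within the scatter). Across these three compounds, the read-out therefore stays within the scatter at this aromatic carbon, para to a large group, even when the ring size changes, sulfur enters and 6-aminopyridin-2-yl with 1 hydrogen-bond donor gives way to 1,2-thiazol-4-yl with 0 hydrogen-bond donors. No measurement shown here offers an explanation for this lack of separation.

All three groups are small aromatic rings, so the compounds shown leave open whether an amine such as piperidine, a carboxylic acid, a plain phenyl ring or a longer alkyl chain at the same place would also stay within the scatter. They also leave open how much the branched alkyl chain on the other side of the shared core contributes, since that chain is identical in compound 1, compound 2 and compound 3.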